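Thiazole to pyrrole exchange on the shared core

A few compounds are considered here, and "the series" means these few. Any claim that something is new, unique, unknown or untested is made for them only; others in the source may bear on it.

Measured so far:
compound 1 `O=C(Nc1ccc(-c2cscn2)cc1)[C@H]1CCCN(Cc2ccc(F)c(F)c2)C1`: 190 nM
compound 2 `O=C(Nc1ccc(-c2cscn2)cc1)C1CCCN(Cc2cccc(C(F)(F)F)c2)C1`: > 20000 nM
compound 3 `O=C(Nc1ccc(-c2nccs2)cc1)C1CCCN(Cc2ccc(F)c(F)c2)C1`: 240 nM

In a functional assay on A-375 cells (Homo sapiens) for antiproliferative activity (on this read-out lower numbers stand for stronger inhibition and higher numbers for weaker inhibition), compound 3 gives 240 nM, the higher of the two numbers reported. Its nearest neighbour is compound 1 with 190 nM, and the gap between the two lies within the usual scatter, so no order between compound 1 and compound 3 can be drawn. For compound 2 the assay reports only a limit, > 20000 nM, and not a number; this is the limit of > 20000 nM in this assay, at which 1 of the 3 values shown sits.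

Compound 4 `O=C(Nc1ccc(-c2ccc[nH]2)cc1)C1CCCN(Cc2ccc(F)c(F)c2)C1` is not yet measured. Relative to compound 3 the change is 1H-pyrrol-2-yl in place of 1,3-thiazol-2-yl on an aromatic carbon. Among the measured compounds shown here, no pair of measured compounds covers an exchange of this kind, so there is no measured step to lean on; compound 1 and compound 3 only show that two arrangements of the five-membered ring with two hetero atoms sit close together.

With the thiazole replaced by a ring of a different heteroatom pattern, a step from compound 3 toward weaker inhibition of moderate size is expected, a 2.5-fold higher number from compound 3 to compound 4 (0.40 log units; beyond the scatter), though it could equally fall inside the scatter. Compound 4 is estimated at 600 nM, with a range from 150 nM to 3000 nM.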

Compound 4, half-maximal inhibitory concentration: 360 nM
For compound 4 the middle estimate is 1.7-fold (0.22 log units) above the measured one; the measured number falls inside the stated range.
By their numbers in this assay, from the lowest: compounds 1, 3 and 4 (each within the scatter of the next). At a limit, above all of these: compound 2.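

In this assay the exchange at this position reads as a small step (a 1.5-fold higher number from compound 3 to compound 4 (0.18 log units; within the scatter)). On an aromatic carbon para to a large group, 1H-pyrrol-2-yl therefore stands in place of 1,3-thiazol-2-yl with no readable loss or gain, although the sulfur is gone and the entering ring carries a hydrogen-bond donor where the leaving ring carries hydrogen-bond acceptors instead. Among the compounds shown here, this is the first single-place exchange at this position, and nothing measured here bears on why the two rings read alike.

Open, as far as these compounds go, is whether the same position also takes a ring with no hetero atom, such as phenyl, or a group of another kind, such as an amine or a carboxylic acid, and whether 1-methylpyrrol-2-yl, which lacks the pyrrole hydrogen, reads the same as 1H-pyrrol-2-yl. Also open, from the compounds shown here alone, is whether this exchange would read the same alongside the trifluoromethyl-bearing group of compound 2, whose > 20000 nM is a limit and not a number.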